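The compounds below may be only part of what the source reports. "The series", "measured", "known", "first", "only" and "open" are said of these compounds alone.

The measured compounds:
Compound 1, `CCN(CC)S(=O)(=O)c1ccc(S(=O)(=O)N2CCC[C@@H](C(=O)N3CCC(F)(F)CC3)C2)cc1`, gives 120 nM in a functional assay on BXPC-3 cells (Homo sapiens) for inhibition, read by MTT assay, with a stated time of 7 days; a lower number here means a stronger inhibitor, a higher number a weaker inhibitor.
Compound 2, `CCN(CC)S(=O)(=O)c1ccc(S(=O)(=O)N2CCC[C@@H](C(=O)N3CCC(COC)CC3)C2)cc1`, gives 1360 nM in this assay.
Compound 3, `CCN(CC)S(=O)(=O)c1ccc(S(=O)(=O)N2CCC[C@@H](C(=O)N3CCC(C(F)F)CC3)C2)cc1`, gives 450 nM in this assay.

Compound 3 stands second highest of the three numbers in this assay. It is separated from compound 1 by a 3.8-fold higher number from compound 1 to compound 3 (0.57 log units; beyond the scatter) and from compound 2 by a 3.0-fold lower number from compound 2 to compound 3 (0.48 log units; beyond the scatter), both beyond the scatter.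

Compound 4, `CCN(CC)S(=O)(=O)c1ccc(S(=O)(=O)N2CCC[C@@H](C(=O)N[C@H]3CCOC3)C2)cc1`, differs from compound 3 in one place: (oxolan-3-yl)amino in place of 4-(difluoromethyl)piperidin-1-yl on a carbonyl carbon. The two measured steps that touch compound 3, a 3.8-fold higher number from compound 1 to compound 3 (0.57 log units; beyond the scatter) and a 3.0-fold lower number from compound 2 to compound 3 (0.48 log units; beyond the scatter), and the step of an 11-fold higher number from compound 1 to compound 2 (1.05 log units; beyond the scatter) all exchange one substituent on the six-membered ring while that ring stays in place. Going by the values given here, no measured pair removes the ring and brings in a smaller five-membered ring with a hydrogen-bond donor, so these steps bear on the change only indirectly. They do show that the numbers move substantially with what stands on the carbonyl carbon. Compound 4 is therefore expected to show a modest move toward a higher number, a 2.0-fold higher number from compound 3 to compound 4 (0.30 log units; within the scatter), with wide uncertainty. Compound 4 is estimated at 900 nM, within a range from 250 nM to 3500 nM.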

Compound 4, half-maximal inhibitory concentration: 5270 nM
The estimate for compound 4 lay 5.9-fold (0.77 log units) below the measured number; the whole stated range lies below it.
By their numbers in this assay, from the lowest: compound 1; then compound 3; then compound 2; then compound 4.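

In this assay, going by these compounds alone, this is the first change at the carbonyl carbon that removes the six-membered ring rather than altering a substituent on it, and it costs more than any of those substituent exchanges suggested: a 12-fold higher number from compound 3 to compound 4 (1.07 log units; beyond the scatter), a 3.9-fold higher number from compound 2 to compound 4 (0.59 log units; beyond the scatter) and a 44-fold higher number from compound 1 to compound 4 (1.64 log units; beyond the scatter). Compound 4 therefore has the highest number of the four, with every step to it beyond the scatter, so the position's range now reaches past 4-(methoxymethyl)piperidin-1-yl, previously the worst group there, and the three piperidine amides all stand clearly ahead of this (oxolan-3-yl)amino amide. No measurement shown here bears on why the number rises.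

This single step changes the ring size, the ring hetero atom, the amide hydrogen and the defined stereocentre together, and the compounds shown cannot separate these. A pyrrolidin-1-yl or a cyclohexylamino group on the same carbonyl carbon, or the opposite stereoisomer of the (oxolan-3-yl)amino group, would begin to tell them apart.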